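The compounds below may be only part of what the source reports. "The series", "measured", "known", "first", "only" and "open" are said of these compounds alone.

Working notes on the series. Two compounds of the shared core have numbers in a functional assay on CV-1 cells for agonist activity at Bile acid receptor (Homo sapiens), read by a luciferase reporter (on this read-out lower numbers stand for an effect already at smaller amounts and higher numbers for an effect only at larger amounts of compound), so far. Compound 1 `Cc1nc(C(=O)O)nc2ccc(-c3ccc(OCc4c(-c5c(Cl)cccc5Cl)noc4C(C)C)cc3)cc12` gives 1000 nM in this assay. For the measured compounds named here, compound 2 `CC(C)c1onc(-c2c(Cl)cccc2Cl)c1COc1ccc(-c2ccc3nc(C(=O)O)cc(O)c3c2)cc1` gives 10000 nM in this assay, the highest of the two numbers; its nearest neighbour, compound 1, lies a step beyond the scatter lower, and no single-site step between them is counted, so the two values are only set side by side.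

Compound 3 `CCCOc1cc(C(=O)O)nc2ccc(-c3ccc(OCc4c(-c5c(Cl)cccc5Cl)noc4C(C)C)cc3)cc12` is not yet measured. It differs from compound 2 in one place: propyl in place of hydrogen on an oxygen on an aromatic ring. No measured pair shows a step of this kind in this assay, so the size of the step from compound 2 to compound 3 can only be guessed. A modest move towards lower numbers, possibly within the scatter, is expected, and compound 3 is estimated at 3000 nM in this assay, with a range from 600 nM to 15000 nM. This estimate means a step of a 3.3-fold lower number from compound 2 to compound 3 (0.52 log units; beyond the scatter) from compound 2.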

Compound 3, half-maximal effective concentration: 22 nM
Compound 3: the middle estimate sits 140-fold (2.13 log units) above what was measured; the measured number lies below the stated range.
By their numbers in this assay, from the lowest: compound 3; then compound 1; then compound 2.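

In this assay, for the compounds shown here, the change from hydroxy to propoxy gives a 450-fold lower number from compound 2 to compound 3 (2.66 log units; beyond the scatter) and is the first single-site step counted, and a large one. It shows that this oxygen on an aromatic ring is a sensitive place in the shared core: putting propyl in place of hydrogen moves the number far towards an effect at smaller amounts of compound. The available data offer no explanation for the size of this step.

The compounds shown leave open whether the step needs propyl in particular or would also come with methoxy, or with a longer chain such as butoxy. They also leave open whether a branched group such as isopropoxy, or an amine carrying propyl in place of propoxy, would keep a number of this order.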